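The compounds below may be only part of what the source reports. "The series", "measured", "known", "first", "only" and "open" are said of these compounds alone.

Measured so far in an ADME assay on 697 cells (Homo sapiens) for cytotoxicity, with a stated time of 48 h; on this read-out higher numbers stand for weaker inhibition and lower numbers for stronger inhibition:
- compound 1 `O=C(NO)c1cc(F)c(Cn2nnc(-c3ccco3)n2)c(F)c1`: > 1000 nM
- compound 2 `Cn1c(Sc2ccc(C(=O)NO)cc2)nnc1-c1cccs1`: > 1000 nM
- compound 3 `Cn1c(Sc2c(F)cc(C(=O)NO)cc2F)nnc1-c1cccs1`: > 1000 nM

Compound 1 gives > 1000 nM, which is a limit of the assay and not a number. It therefore has no exact place in the series, and the same holds for compound 2 and compound 3. The shared reading is the limit of > 1000 nM in this assay, at which 3 of the 3 values shown sit. For the measured compounds named here, no step between measured compounds is available.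

Compound 4 `Nc1ccc(-c2nnn(Cc3c(F)cc(C(=O)NO)cc3F)n2)cc1` is still unmeasured. It keeps the core of compound 1 and differs as follows: 4-aminophenyl in place of furan-2-yl on an aromatic carbon. In words, this is 4-aminophenyl in place of furan-2-yl on an aromatic carbon.

In this assay, no clear move towards stronger inhibition is expected, and a reading that is again only a limit is the likeliest outcome. The expected change is modest, and the estimate is a step that the limit leaves unreadable from compound 1 to compound 4. For compound 4 the estimated value is 2000 nM, with an expected range from 700 nM to 8000 nM.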

Compound 4, half-maximal inhibitory concentration: > 1000 nM
Compound 4: only a limit was reported; the forecaster's own chance of this, stated with the estimate: 70%; the middle value is on the limit's open side.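

No step from compound 1 to compound 4 can be read, because both stand at the same limit and not at a number: the limit of > 1000 nM in this assay, at which 4 of the 4 values shown sit.

Still open, from the compounds shown here alone, is whether 4-aminophenyl in place of furan-2-yl changes the read-out at all, and what exact values compound 1 and compound 4 would have.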